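The source may hold more compounds than are shown below. What is called first, only, known or untested is meant among the compounds shown, and "the series" means these compounds.

Working notes on the diamine series. All four compounds share one core; the point of variation is the substituent on the remaining ring position. Compound 1 `Nc1cc(N)c2nc(-c3ccccc3)c(NCc3ccc(Cl)c(Cl)c3)nc2c1` carries a 3,4-dichlorophenyl on an aminomethyl linker, compound 3 `Nc1cc(N)c2nc(-c3ccccc3)c(Sc3ccc(F)cc3)nc2c1` a (4-fluorophenyl)sulfanyl, and compound 2 `CCOC(=O)[C@H](CCC(=O)O)NC(=O)c1ccc(Sc2nc3cc(N)cc(N)c3nc2-c2ccccc2)cc1` a much larger substituent on the sulfur.

In a functional assay on HCT-116 cells (Homo sapiens) for inhibition, read by sulforhodamine B assay, with a stated time of 48 h (on this read-out higher numbers stand for weaker inhibition of growth and lower numbers for stronger inhibition of growth), compound 1 gives 24000 nM. In this assay compound 3 gives 28200 nM; compound 3 and compound 1 lie within the scatter of each other, so no order between them is claimed. For compound 2 the read in this assay is a limit, < 100000 nM, the one limit among the three results, as recorded in the limit of < 100000 nM in this assay, at which 1 of the 3 values shown sits.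

Compound 4 `Nc1cc(N)c2nc(-c3ccccc3)c(Sc3ccc(Cl)c(Cl)c3)nc2c1` is not yet measured. It differs from compound 3 in one place: 3,4-dichlorophenyl in place of 4-fluorophenyl on a sulfur. For the measured compounds named here, compound 1, which already presents the 3,4-dichlorophenyl on another linker, sits within the scatter of compound 3, so no measured step suggests that this change moves the number far. The step of a 1.9-fold lower number from compound 3 to compound 4 (0.27 log units; within the scatter) is expected to be small, at most a modest move towards stronger growth inhibition. Compound 4 is estimated at 15000 nM, with a range from 5000 nM to 45000 nM.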

Compound 4, concentration for total growth inhibition: 47900 nM
The estimate for compound 4 lay 3.2-fold (0.50 log units) below the measured number; the measured number lies above the stated range.
By their numbers in this assay, from the lowest: compounds 1, 3 and 4 (each within the scatter of the next).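

Placing 3,4-dichlorophenyl in place of 4-fluorophenyl on a sulfur is the first change in the series that can be read in one place, and in this assay it gives a 1.7-fold higher number from compound 3 to compound 4 (0.23 log units; within the scatter). The step shows that, with the sulfur and the shared core held constant, this exchange of one halogenated phenyl group for the other does not separate the two compounds beyond the scatter, and the move towards stronger inhibition of growth that compound 1 might have suggested does not appear. No measured property shown here bears on this step, so the data give no account of it.

As far as these compounds go, only these two phenyl groups on the sulfur can be compared directly, so the effect of an amine or a carboxylic acid in place of the chlorine atoms, or of a longer chain on the sulfur, remains open. In this assay, from the compounds shown here alone, compound 2 gives < 100000 nM, which is a limit and not a number, so the effect of its much larger substituent on the sulfur also remains open.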